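The source may report more compounds than this note shows. Statements on the series, on what has been measured and on what is new or still open speak of the compounds shown alone.

The study follows antiproliferative activity in a functional assay on ECa-109 cells (Homo sapiens) for antiproliferative activity, read by MTT assay, with a stated time of 72 h (a higher number here means a weaker inhibitor, a lower number a stronger inhibitor), across a small set of compounds sharing one core. Compound 1 `CCCSc1nc(N/N=C(\C)c2ccccc2O)c2nnn(Cc3ccco3)c2n1` gives 5760 nM in this assay. Compound 3 `COc1cc(/C=N/Nc2nc(SCc3ccccc3)nc3c2nnn3Cc2ccccc2)cc(OC)c1OC` gives 4400 nM in this assay, and the two numbers lie within the usual scatter of one another, so neither can be placed above the other. Compound 2 `CCCSc1nc(N/N=C/c2cccnc2)c2nnn(Cc3ccccc3)c2n1` returns only a limit in this assay, namely > 64000 nM, and no number is known for it. Among the three values one sits at the limit of > 64000 nM in this assay, at which 1 of the 3 values shown sits.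

Compound 4 `CCCSc1nc(N/N=C(\C)c2ccccc2O)c2nnn(Cc3ccc(O)cc3)c2n1` has not yet been measured. It differs from compound 1 in one place: 4-hydroxyphenyl in place of furan-2-yl on a saturated chain carbon bound to an aromatic nitrogen. Within the data shown here, no measured pair in this set shows this change, so its effect in this assay is unknown from the data. The step from compound 1 to compound 4 is expected to be a 1.0-fold lower number from compound 1 to compound 4 (0.02 log units; within the scatter), a change not beyond the scatter. Compound 4 is therefore estimated at 5500 nM in this assay, within a range from 2000 nM to 16000 nM.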

Compound 4, half-maximal inhibitory concentration: 15900 nM
Compound 4: middle estimate off by 2.9-fold (0.46 log units), on the low side; the measured number falls inside the stated range.
By their numbers in this assay, from the lowest: compounds 3 and 1 (each within the scatter of the next); then compound 4. At a limit, above all of these: compound 2.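

Among these compounds, this is the first step in the set that can be read at this position. With the rest of compound 1 held fixed, 4-hydroxyphenyl in place of furan-2-yl on a saturated chain carbon bound to an aromatic nitrogen moves the number upward in this assay (a 2.8-fold higher number from compound 1 to compound 4 (0.44 log units; beyond the scatter)). The position is therefore not indifferent to its group, although the step is modest, and nothing measured here bears on why the number moved.

As far as these compounds go, whether the change of ring or the hydroxyl carries the step stays open, and a plain benzyl or a 4-methoxybenzyl group in this place on the core of compound 1 would separate the two. From the compounds shown here alone, how a carboxylic acid or an amine on the same ring would read in this assay also remains unknown.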